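The compounds below may be only part of what the source reports. "The series", "measured", "known", "first", "only" and "open" are said of these compounds alone.

Compound 1 `COc1cc2c(Nc3nc4ccc(C(=O)Nc5c(C)cc(C)cc5C)cc4s3)ncnc2cc1OCCCN1CCC(C)CC1`: 7000 nM
Compound 2 `COc1cc2c(Nc3nc4ccc(C(=O)Nc5c(C)cccc5C)cc4s3)ncnc2cc1OCCCN1CCCC1`: > 100000 nM

Of the compounds shown here, two have been tested in a functional assay on DLD-1 cells (Homo sapiens) for cytotoxicity, read by WST assay, with a stated time of 72 h; a lower number here means a stronger inhibitor, a higher number a weaker inhibitor. Compound 1 gives a measured number, 7000 nM. Compound 2 gives only a limit of the assay, > 100000 nM, so no exact number is known for it; it is one of the values sitting at the limit of > 100000 nM in this assay, at which 1 of the 2 values shown sits. Compound 2 thus stands at the weak edge of what the assay can report, and the two values can only be said to differ in kind, one a number and one a limit.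

Compound 3 `CCN(CC)CCCOc1cc2ncnc(Nc3nc4ccc(C(=O)Nc5c(C)cccc5C)cc4s3)c2cc1OC` has not yet been measured in this assay. It differs from compound 2 in one place: diethylamino in place of pyrrolidin-1-yl on a saturated chain carbon, three bonds along the chain from an oxygen on an aromatic ring. For the measured compounds named here, no pair of measured compounds differing in one place is available, so the size of this step cannot be read from data. The expected step of a number no higher from compound 2 to compound 3 (the limit leaves the size open) is none beyond the scatter, with no clear direction. Compound 3 is estimated at 100000 nM, with a range from 30000 nM to 300000 nM.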

Compound 3, half-maximal inhibitory concentration: > 100000 nM
Compound 3 gave a limit, no number; the forecaster's own chance of this, stated with the estimate: 60%; the middle value sits exactly at the limit.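

In this assay compound 3 gives > 100000 nM, which is a limit of the assay and not a number. Compound 2 also gives only a limit, so no step between compound 2 and compound 3 can be read: the limit of > 100000 nM in this assay, at which 2 of the 3 values shown sit.

As far as these compounds go, what stays open is how far past the limit each of these two compounds lies, and whether diethylamino in place of pyrrolidin-1-yl changes the result at all.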